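Removing the Ester Methyl on the Shared Core

A few compounds are considered here, and "the series" means these few. Any claim that something is new, unique, unknown or untested is made for them only; others in the source may bear on it.

Compound 3 `COC(=O)C1=Cc2ccc(OC)cc2OC1c1cc(OC)c(OC)c(OC)c1` carries a methoxycarbonyl group on a double-bonded ring carbon, where compound 1 `COc1ccc2c(c1)OC(c1cc(OC)c(OC)c(OC)c1)C(CO)=C2` has hydroxymethyl and compound 2 `CCOCC1=Cc2ccc(OC)cc2OC1c1cc(OC)c(OC)c(OC)c1` has ethoxymethyl. In a functional assay for inhibition of nuclear factor NF-kappa-B complex (Homo sapiens) (on this read-out lower numbers stand for stronger inhibition and higher numbers for weaker inhibition), compound 1 reaches only the assay limit of > 50000 nM. In this assay compound 2 gives 21300 nM and compound 3 gives 13800 nM, the two within the scatter of each other. Compound 4 `COc1ccc2c(c1)OC(c1cc(OC)c(OC)c(OC)c1)C(C(=O)O)=C2` differs from compound 3 by hydrogen in place of methyl on an oxygen next to a carbonyl group. Within the data shown here, no measured step removes this methyl; the steps of an at least 3.6-fold lower number from compound 1 to compound 3 (0.55 log units; beyond the scatter) and a 1.5-fold lower number from compound 2 to compound 3 (0.19 log units; within the scatter) only show that exchanges at this ring carbon move this assay modestly. For compound 4 a small change, expected as a 1.8-fold higher number from compound 3 to compound 4 (0.26 log units; within the scatter), is therefore estimated, giving an expected value of 25000 nM within 8000 nM to 80000 nM.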

Compound 4, half-maximal inhibitory concentration: > 50000 nM
Compound 4: only a limit was reported (the forecaster's own chance of this, stated with the estimate: 30%); middle value at least 2.0-fold (0.30 log units) away from the limit.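

In this assay, the single methyl on the ester oxygen counts: putting hydrogen in its place gives an at least 3.6-fold higher number from compound 3 to compound 4 (0.55 log units; beyond the scatter), and carboxy in place of ethoxymethyl gives an at least 2.3-fold higher number from compound 2 to compound 4 (0.37 log units; beyond the scatter). Among these compounds, both with hydrogen on the oxygen at this ring carbon's substituent, compound 1 and compound 4, give only limits, whereas compound 2 and compound 3, with that oxygen capped, give readable numbers. The value of compound 4 is a limit, and the step between the two limits cannot be read: the limit of > 50000 nM in this assay, at which 2 of the 4 values shown sit.

As far as these compounds go, whether an ethyl ester or an amide at this ring carbon would give a number like that of compound 3 stays open.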